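The source may hold more compounds than are shown below. What is called first, only, known or untested is meant among the compounds shown, and "the series" means these compounds.

Measured so far:

Compound 1, `CCOC(=O)C1=C(C)NC(=O)NC1C1CCCC1` — in an assay on HEK293 cells for displacement of a labelled ligand from adenosine receptor A2b (Homo sapiens), with a stated time of 30 min, tested at 1 uM (on this read-out lower numbers stand for less inhibition and higher numbers for more inhibition at the one concentration tested (going by the name of the read-out)), compound 1 gives 2%.
Compound 2, `CC1=C(C(=O)OC(C)C)C(C2CCCC2)N/C(=N/C#N)N1` — in this assay compound 2 gives 11%.
Compound 3, `CC1=C(C(=O)OC(C)C)C(c2ccccc2)NC(=O)N1` — in this assay compound 3 gives 2%.

The number for compound 2 is the top one of the three shown, yet its gap to compound 1 and its gap to compound 3 both lie within the usual scatter of repeated measurements, so on these numbers the three compounds cannot be told apart: all three sit in the region of weak inhibition.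

Compound 4, `CCOC(=O)C1=C(C)N/C(=N\C#N)NC1C1CCCC1`, has not yet been measured in this assay. It differs from compound 2 in one place: hydrogen in place of methyl on a saturated chain carbon bound to an oxygen next to a carbonyl group and a saturated chain carbon. The ester chain is shortened by one carbon; nothing else in the shared core changes.

Among the compounds with values here, no pair of measured compounds differs in just one place, so there is no measured step to lean on. The three measured numbers are all small and indistinguishable, and the change here is small. The expected step from compound 2 to compound 4 is a number 3 percentage points lower from compound 2 to compound 4 (within the scatter), that is, no movement beyond the scatter in either direction. For compound 4 the expected inhibition is therefore 8%, with a likely range from 0% to 20%.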

Compound 4, a percentage reported as inhibition, at one concentration (the size of the read-out at that concentration, not a potency): 19%
Compound 4: middle estimate off by 11 percentage points, on the low side, within the range that was stated.
By their numbers in this assay, from the lowest: compounds 1, 3, 2 and 4 (each within the scatter of the next, the first and the last beyond it).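

Within the data shown here, this is the first pair of measured compounds that differ in one place, so the change from isopropoxycarbonyl to ethoxycarbonyl can now be read directly in this assay: the result is a number 8 percentage points higher from compound 2 to compound 4 (within the scatter). Removing this one carbon from the ester chain therefore produces no change that can be told apart from ordinary repeat variation, and on this single pair, ethyl and isopropyl cannot be distinguished at this place. No supporting measurement is available to explain this result.

Going by these compounds, it remains open whether a larger change here, such as a longer chain, a benzyl group or a carboxylic acid in place of the ester, would move inhibition beyond the scatter. On these data alone, with only one tested concentration, any potency difference between compound 2 and compound 4 also remains unknown.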